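Opening the Disulfide Ring of Compound 2

This account rests on a few compounds, and the source may have more. Where it says the series, first, only, none or still open, it means among the compounds named here.

Measured in a functional assay on NCI-H460 cells (Homo sapiens) for inhibition, read by MTT assay, with a stated time of 24 h, tested at 0.1 ug/mL; a higher number here means more inhibition of growth at the concentration tested, a lower number less inhibition of growth:

Compound 1 `O=C(CCCCC(S)CCS)NO` gives 5.7%
Compound 2 `O=C(CCCCC1CCSS1)Nc1ccc([N+](=O)[O-])c(C(F)(F)F)c1` gives 18.8%
Compound 3 `O=C(CCCCC(S)CCS)Nc1ccccc1Cl` gives 6.36%

In this assay compound 2 stands highest of the three, and its lead over each of the other two lies beyond the usual scatter. Compound 4 `O=C(CCCCC(S)CCS)Nc1ccc([N+](=O)[O-])c(C(F)(F)F)c1` differs from compound 2 by a group of 5 heavy atoms (3 carbon, 2 sulfur; no ring) in place of a group of 5 heavy atoms (3 carbon, 2 sulfur; one five-membered non-aromatic ring with 2 hetero atoms), on a saturated chain carbon, four bonds along the chain from a carbonyl carbon and the 1,3-disulfanylpropyl group that enters is also carried by compound 1 and compound 3. Going by the values given here, those two compounds differ from compound 4 elsewhere in the structure, and no measured pair shows this change alone. Still, the expectation leans downward, since compound 1 gives 5.7% and compound 3 gives 6.36% with that open chain. The expected step is a modest fall, estimated at a number 6.8 percentage points lower from compound 2 to compound 4 (within the scatter) and so within the usual scatter. For compound 4 an estimated 12% is expected, with a range from 4% to 24% in repeated measurements.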

Compound 4, percent growth inhibition at one concentration: 3.2%
Beside the measured number, compound 4's estimate is 8.8 percentage points above it, outside the stated range (below it).
By their numbers in this assay, from the lowest: compounds 4, 1 and 3 (each within the scatter of the next); then compound 2.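

Compound 2 and compound 4 differ only on the saturated chain carbon, four bonds along the chain from a carbonyl carbon, so this pair isolates the change from the ring to the open chain. In this assay, the step of a number 15.6 percentage points lower from compound 2 to compound 4 (beyond the scatter) comes with the 1,3-disulfanylpropyl group taking the place of the five-membered non-aromatic ring, with the rest of the structure unchanged. Nothing among the available data accounts for this difference between the ring and the open chain.

Whether closing the open chain would raise the inhibition of growth in compound 1 or compound 3 stays open, as no ring-bearing partner of either is shown. Also open, on these data alone, is whether a six-membered ring holding both sulfur atoms, or a chain ending in methylthio groups, would stand nearer compound 2 or compound 4.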